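The source may hold more compounds than are shown below. What is called first, only, known or untested is meant among the compounds shown, and "the series" means these compounds.

Series notes, A549 growth inhibition

Three compounds have numbers in a functional assay on A549 cells (Homo sapiens) for inhibition, read by MTT assay, with a stated time of 48 h (a lower number here means a stronger inhibitor, a higher number a weaker inhibitor), so far. Compound 1 `COc1ccc(N(C)c2nc(C)nc3ccccc23)cc1OCCC[Se]C#N` gives 382 nM. Compound 2 `COc1ccc(N(C)c2nc(C)nc3ccccc23)cc1OCCCC[Se]C#N` gives 1200 nM. Compound 3 `COc1ccc(N(C)c2nc(C)nc3ccccc23)cc1C(=O)OCCCCCC[Se]C#N` gives 488 nM.

Compound 2 and compound 1 share a core and differ in one place: a group of 3 heavy atoms (1 carbon, 1 nitrogen, 1 selenium; no ring) in place of a group of 4 heavy atoms (2 carbon, 1 nitrogen, 1 selenium; no ring), on a saturated chain carbon, three bonds along the chain from an oxygen on an aromatic ring. That change gives a 3.1-fold lower number from compound 2 to compound 1 (0.50 log units; beyond the scatter). Compound 3 carries a different core from compound 2, and the difference between the two cores is not broken down here. Against compound 1, compound 3 stands within the usual scatter, so no order between these two is read; against compound 2 its number is lower by a margin beyond the scatter.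

Compound 4 `COc1ccc(N(C)c2nc(C)nc3ccccc23)cc1C(=O)OCCCCC[Se]C#N` is not yet measured. It differs from compound 3 in one place: a group of 3 heavy atoms (1 carbon, 1 nitrogen, 1 selenium; no ring) in place of a group of 4 heavy atoms (2 carbon, 1 nitrogen, 1 selenium; no ring), on a saturated chain carbon, five bonds along the chain from an oxygen next to a carbonyl group. Next to the change from compound 2 to compound 1 this is the same kind of change, though not the same: there the place was three bonds along the chain from an oxygen on an aromatic ring, here it is five bonds along the chain from an oxygen next to a carbonyl group. Among the compounds with values here, the step from compound 3 to compound 4 is expected to be a 2.4-fold lower number from compound 3 to compound 4 (0.39 log units; beyond the scatter), set beside a 3.1-fold lower number from compound 2 to compound 1 (0.50 log units; beyond the scatter), and that expectation rests only on the one measured pair, compound 2 and compound 1, with the chain attachment differing. For compound 4 the expected number in this assay is 200 nM, with a range of 80 nM to 550 nM.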

Compound 4, half-maximal inhibitory concentration: 592 nM
For compound 4 the middle estimate is 3.0-fold (0.47 log units) below the measured one, and the stated range ends below it.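

In this assay, the group of 3 heavy atoms in place of the group of 4 heavy atoms gives a 1.2-fold higher number from compound 3 to compound 4 (0.08 log units; within the scatter), so no effect of this change is read on the core of compound 3. The step seen on the core of compound 1 therefore does not carry over to the core of compound 3 at its measured size, and the two steps differ: the same change on two cores in this assay, a 3.1-fold lower number (0.50 log units; beyond the scatter) from compound 2 to compound 1 and a 1.2-fold higher number (0.08 log units; within the scatter) from compound 3 to compound 4, 3.8-fold (0.58 log units) apart, beyond the scatter of two such steps

This shows that, within these two pairs, the result of the change cannot be taken from one core to the other, but it does not show what sets the two steps apart, since the place also differs, three bonds along the chain from an oxygen on an aromatic ring in one pair and five bonds along the chain from an oxygen next to a carbonyl group in the other.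

The compounds shown leave open whether the difference follows the core or the chain attachment, which a chain of matching length on each attachment could separate. They also leave open how a still shorter or longer chain would read on either core, and whether a sulfur atom in place of selenium, or an amide in place of the ester, would leave the picture unchanged.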